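The source may report more compounds than this note shows. Statements on the series, on what has been measured and on what is new or still open speak of the compounds shown alone.

Compound 1 `CCCCc1oc2ccccc2c1C(=O)c1ccc(OCC(N)=O)cc1`: > 50000 nM, a limit of the assay.
Compound 2 `CCCCc1oc2ccccc2c1C(=O)c1ccc(OCC(=O)N2CCCCC2)cc1`: > 50000 nM, a limit of the assay.
Compound 3 `CCCCc1oc2ccccc2c1C(=O)c1ccc(OCC(=O)N2CCOCC2)cc1`: 34000 nM.

For the measured compounds named here, in a functional assay on MCF7 cells (Homo sapiens) for antiproliferative activity, read by MTT assay, with a stated time of 24 h (a lower number here means a stronger inhibitor, a higher number a weaker inhibitor), compound 3 gives 34000 nM, the only actual number of the three; the rest is the limit of > 50000 nM in this assay, at which 2 of the 3 values shown sit. Compound 4 `CCCCc1oc2ccccc2c1C(=O)c1ccc(OCC(=O)Nc2cccc(OC)c2)cc1` carries (3-methoxyphenyl)amino in place of morpholin-4-yl on a carbonyl carbon. The measured steps at this carbonyl carbon are a step that the two limits leave unreadable from compound 1 to compound 2, an at least 1.4-fold lower number from compound 1 to compound 3 (0.16 log units; that floor lies within the scatter) and an at least 1.4-fold lower number from compound 2 to compound 3 (0.16 log units; that floor lies within the scatter). None of them has a size beyond the scatter, and none brings in an aromatic ring. The expected step is therefore a 1.1-fold lower number from compound 3 to compound 4 (0.05 log units; within the scatter), with no shift beyond the scatter in either direction. The estimate for compound 4 is 30000 nM, with an expected range of 12000 nM to 50000 nM.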

Compound 4, half-maximal inhibitory concentration: 38500 nM
For compound 4 the middle estimate is 1.3-fold (0.11 log units) below the measured one; the measured number falls inside the stated range.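

In this assay, for the compounds shown here, an aromatic ring and a hydrogen-bond donor enter at this carbonyl carbon for the first time, and the outcome is a 1.1-fold higher number from compound 3 to compound 4 (0.05 log units; within the scatter). The aromatic (3-methoxyphenyl)amino group and the non-aromatic morpholin-4-yl group are therefore not told apart here. Only floors can be read for the other two comparisons, an at least 1.2-fold lower number from compound 2 to compound 4 (0.11 log units; that floor lies within the scatter) and an at least 1.2-fold lower number from compound 1 to compound 4 (0.11 log units; that floor lies within the scatter), and each rests on a limit: the limit of > 50000 nM in this assay, at which 2 of the 4 values shown sit.

Open, on these data alone, is how phenylamino without the methoxy group, or a longer chain carrying an amine, would read on this carbonyl carbon. Also open, as far as these compounds go, is whether any group here shifts the number beyond the scatter.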